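The compounds below may be only part of what the source reports. "The series", "measured", "known", "first", "only" and "open" are said of these compounds alone.

Measured compounds:
- compound 1 `Cc1ccccc1-c1nc(CN2CCC(C(=O)NCCCN3CCC(C(C)C)CC3)CC2)c(C)o1` — in a physicochemical assay for permeability, using PAMPA (a higher number here means that the compound crosses the layer faster, a lower number that the compound crosses the layer more slowly), compound 1 gives 396 10^-6 cm/s
- compound 2 `Cc1cccc(Cl)c1-c1nc(CN2CCC(C(=O)NCCCN3CCC(C)(C)CC3)CC2)c(C)o1` — for compound 2 the result in this assay is "not determined" (no result reported)
- compound 3 `Cc1oc(-c2c(Cl)cccc2C(F)(F)F)nc1CN1CCC(C(=O)NCCCN2C[C@H](C)C[C@H](C)C2)CC1` — for compound 3 the result in this assay is "not determined" (no result reported)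

For the measured compounds named here, compound 3 therefore stands without a number in this assay; compound 2 is in the same position, so compound 1 is the only member of the series with a measured value, and no step between two measured compounds can be drawn. The unmeasured compound 4 `COc1ccc(-c2nc(CN3CCC(C(=O)NCCCN4C[C@H](C)C[C@H](C)C4)CC3)c(C)o2)cc1OC` differs from compound 3 in one place: 3,4-dimethoxyphenyl in place of 2-chloro-6-(trifluoromethyl)phenyl on an aromatic carbon.

Going by the values given here, with no measured step, the size of the step from compound 3 to compound 4 in this assay cannot be read from the data; the expectation is a change of no more than a moderate size, in either direction, and it may well fall within the scatter. Among the compounds with values here, the only anchor is compound 1, which gives 396 10^-6 cm/s, so the series as far as it is measured sits in the fast-crossing range. Compound 4 is estimated at 250 10^-6 cm/s in this assay, with a range from 90 10^-6 cm/s to 550 10^-6 cm/s.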

Compound 4, apparent permeability: 81.9 10^-6 cm/s
Estimate against measurement, compound 4: 3.1-fold (0.48 log units) above; measured number outside the range, below it.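

In this assay compound 4 gives 81.9 10^-6 cm/s while compound 3 stands without a number, so no new step can be read. Still open, going by these compounds, is how 3,4-dimethoxyphenyl and 2-chloro-6-(trifluoromethyl)phenyl compare at this place. No available evidence bears on this result.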